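A few compounds are considered here, and "the series" means these few. Any claim that something is new, unique, unknown or untested is made for them only; others in the source may bear on it.

Measured so far:
- Compound 1 `C=C1C[C@]23C[C@@]1(O)CC[C@H]2c1ccc(OS(=O)(=O)c2ccc(C)cc2)c(C)c1[C@@H]3Cn1cc(-c2ccc(Br)cc2)nn1`: in a functional assay on SW480 cells (Homo sapiens) for cytotoxicity, read by MTT assay, with a stated time of 4 days (a lower number here means a stronger inhibitor, a higher number a weaker inhibitor), compound 1 gives > 20000 nM, which is a limit of the assay.
- Compound 2 `C=C1C[C@]23C[C@@]1(O)CC[C@H]2c1ccc(O)c(C)c1[C@@H]3Cn1cc(-c2ccc(Br)cc2)nn1`: in this assay compound 2 gives > 20000 nM, again a limit.
- Compound 3 `C=C1C[C@]23C[C@@]1(O)CC[C@@H]2c1cccc(C)c1[C@@H]3Cn1cc(-c2ccccn2)nn1`: in this assay compound 3 gives > 20000 nM, also a limit.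

All three values therefore sit at the same limit, as the limit of > 20000 nM in this assay, at which 3 of the 3 values shown sit, records. Going by the values given here, the one step between measured compounds, a step that the two limits leave unreadable from compound 1 to compound 2, cannot be read for that reason. Compound 3 thus stands where every measured compound stands: only a limit is known for it, and nothing separates it from compound 1 or compound 2.

Compound 4 `C=C1C[C@]23C[C@@]1(O)CC[C@@H]2c1cccc(C)c1[C@@H]3Cn1cc(-c2ccc(C(F)(F)F)cc2)nn1` is the next compound. The change from compound 3 is 4-(trifluoromethyl)phenyl in place of pyridin-2-yl on an aromatic carbon. Among the compounds with values here, no measured step bears on this change, since each step so far is hidden by the limit. The expectation for the step from compound 3 to compound 4 is therefore a step that the limit leaves unreadable from compound 3 to compound 4, meaning no change that can be read. Compound 4 is expected to give 25000 nM, within 6000 nM to 80000 nM, most likely reported as a limit again.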

Compound 4, half-maximal inhibitory concentration: > 20000 nM
Compound 4: only a limit was reported; the forecaster's own chance of this, stated with the estimate: 75%; the middle value is on the limit's open side.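

No new step can be read between compound 3 and compound 4, since this assay gives only a limit for each: the limit of > 20000 nM in this assay, at which 4 of the 4 values shown sit.
The compounds shown leave open which change to the shared core, if any, would give a readable number in this assay at all.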